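The compounds below may be only part of what the source reports. "The series", "measured", "known", "first", "only" and "open" are said of these compounds alone.

Compound 3 `CN(C)c1nc2ccc(NC(=O)CCc3ccc(C(F)(F)F)cc3)cc2[nH]1` carries a dimethylamino group on the shared core and gives 12 nM in an assay on CHO-K1 cells for displacement of a labelled ligand from melanin-concentrating hormone receptor 1 (Homo sapiens), read by scintillation counting; a higher number here means a weaker inhibitor, a lower number a stronger inhibitor. Among the three measured compounds it holds the second highest number. Compound 1 `CN(c1nc2ccc(NC(=O)CCc3ccc(C(F)(F)F)cc3)cc2[nH]1)C1CC1`, with a cyclopropyl on that nitrogen, gives 24 nM, and this pair lies within the scatter. Compound 2 `CC(C)N(C)c1nc2ccc(NC(=O)CCc3ccc(C(F)(F)F)cc3)cc2[nH]1`, with an isopropyl there, gives 5.9 nM, and there is a 2.0-fold higher number from compound 2 to compound 3 (0.31 log units; beyond the scatter). Compound 4 `CN(c1nc2ccc(NC(=O)CCc3ccc(C(F)(F)F)cc3)cc2[nH]1)C1CCCCC1` differs from compound 3 by cyclohexyl in place of methyl on a nitrogen on an aromatic ring. The measured steps that bear on this change all concern the same nitrogen: a 2.0-fold lower number from compound 1 to compound 3 (0.30 log units; within the scatter), which stays within the scatter, and a 4.1-fold lower number from compound 1 to compound 2 (0.61 log units; beyond the scatter), which lies beyond it. Of the two measured enlargements on this nitrogen, one gave a lower number and one no change beyond the scatter, so for compound 4 a modest move toward a lower number, or none beyond the scatter, is expected, namely a 1.5-fold lower number from compound 3 to compound 4 (0.18 log units; within the scatter). Compound 4 is therefore estimated at 8 nM, with a range from 3 nM to 25 nM.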

Compound 4, half-maximal inhibitory concentration: 6.7 nM
Compound 4: middle estimate off by 1.2-fold (0.08 log units), on the high side; the measured number falls inside the stated range.
By their numbers in this assay, from the lowest: compounds 2, 4, 3 and 1 (each within the scatter of the next, the first and the last beyond it).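

Cyclohexyl, with six heavy atoms in place of the single carbon of methyl, keeps the number within the scatter (a 1.8-fold lower number from compound 3 to compound 4 (0.25 log units; within the scatter)), so a six-membered carbon ring is accommodated on this nitrogen in this assay. It also stays within the scatter of isopropyl (a 1.1-fold higher number from compound 2 to compound 4 (0.06 log units; within the scatter)), whereas the step from cyclopropyl lies beyond it (a 3.6-fold lower number from compound 1 to compound 4 (0.55 log units; beyond the scatter)), which shows that a carbon ring on this nitrogen does not by itself set the number. No measurement at hand accounts for the gap between these two rings.

The compounds shown leave open how a phenyl or a longer chain such as n-butyl on this nitrogen would read in this assay. They also leave open whether a cyclohexyl bearing a hydroxyl group would hold its place, and whether the remaining methyl could give way to hydrogen.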